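Replacing the Bromophenyl Amide Ring in a Paw-Edema Series

The source may hold more compounds than are shown below. What is called first, only, known or untested is meant among the compounds shown, and "the series" means these compounds.

Compound 1 `COc1cc2c(cc1OC)C(CC(=O)O)CC2`: 26.7% in a functional assay on the whole organism (strain Wistar) for inhibition, with Rattus norvegicus as the target, read by paw edema, with a stated time of 24 h, at a dose of 100 mg/kg; a lower number here means less inhibition, a higher number more inhibition at the dose given (going by the name of the read-out).
Compound 2 `COc1cc2c(cc1OC)C(CC(=O)Nc1ccc(Cl)cc1)CC2`: 70%.
Compound 3 `COc1cc2c(cc1OC)C(CC(=O)Nc1ccc(Br)cc1)CC2`: 66.7%.

Compound 3 stands second highest of the three numbers. The two steps that end at compound 3 are a number 3.3 percentage points lower from compound 2 to compound 3 (within the scatter) and a number 40 percentage points higher from compound 1 to compound 3 (beyond the scatter), so the amide series sits far above the acid while the two halogen amides lie together. Compound 4 `COc1cc2c(cc1OC)C(CC(=O)Nc1ccccc1C)CC2` differs from compound 3 by 2-methylphenyl in place of 4-bromophenyl on an amide-type nitrogen. Among the compounds with values here, only the step from compound 2 to compound 3 touches this ring, and it stayed within the scatter; no measured step changes the ring's substituent position or exchanges a halogen for a methyl. With the amide kept, a step of no more than modest size is expected, in either direction. Compound 4 is therefore estimated at about 60%, within 42% to 76%. The expected step is a number 6.7 percentage points lower from compound 3 to compound 4 (within the scatter).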

Compound 4, a percentage reported as inhibition, in the whole organism at one dose (the size of the read-out at that dose, not a potency): 23.3%
Compound 4: the middle estimate sits 36.7 percentage points above what was measured; measured number outside the range, below it.
By their numbers in this assay, from the lowest: compounds 4 and 1 (each within the scatter of the next); then compounds 3 and 2 (each within the scatter of the next).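

In this assay, the group on the amide-type nitrogen matters greatly: 2-methylphenyl in place of 4-bromophenyl gives a number 43.4 percentage points lower from compound 3 to compound 4 (beyond the scatter), and in place of 4-chlorophenyl it gives a number 46.7 percentage points lower from compound 2 to compound 4 (beyond the scatter). Having an amide is therefore not enough to lift a compound above the acid, as (2-methylphenyl)amino in place of hydroxy gives a number 3.4 percentage points lower from compound 1 to compound 4 (within the scatter). No measurement at hand accounts for this loss.

This change swaps the halogen for a methyl and also moves the substituent, so the two changes cannot be told apart here. A 4-methylphenyl or 2-chlorophenyl group on the same nitrogen would separate them.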